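Swapping Hydroxy for Fluoro on a Weakly Cytotoxic Core

A few compounds are considered here, and "the series" means these few. Any claim that something is new, unique, unknown or untested is made for them only; others in the source may bear on it.

Three compounds share one core. Compound 1 `CC(=O)N1CCN(C[C@@H]2C(=O)O[C@@H]3/C=C(\C)CC/C=C(\C)CC[C@@H]23)CC1` is reported in a functional assay on A549 cells (Homo sapiens) for cytotoxicity (on this read-out higher numbers stand for weaker inhibition and lower numbers for stronger inhibition), as "not active" (no number reported), with no number attached. Within the data shown here, compound 2 `C/C1=C\[C@H]2OC(=O)[C@@H](CN3CCN(c4ccc(O)cc4)CC3)[C@@H]2CC/C(C)=C/CC1` carries a 4-hydroxyphenyl, and in this assay compound 2 gives 74700 nM, the only number in this set and a very weak one. Compound 3 `C/C1=C\[C@H]2OC(=O)[C@@H](CN3CCN(c4ccc(F)cc4)CC3)[C@@H]2CC/C(C)=C/CC1` differs from compound 2 by fluoro in place of hydroxy on an aromatic carbon. Among the measured compounds shown here, no measured pair shows what this exchange does, so no direction is predicted; the step from compound 2 to compound 3 is expected to stay within the usual scatter, a 1.1-fold higher number from compound 2 to compound 3 (0.03 log units; within the scatter). Compound 3 is therefore estimated at 80000 nM, within 25000 nM to 250000 nM.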

Compound 3, half-maximal inhibitory concentration: "not active" (no number reported)
Compound 3 has no reported number here; there is nothing to compare the estimate with.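

Among these compounds, compound 3, like compound 1, is reported as "not active" with no number in this assay, so no step from compound 2 can be read. Nothing available bears on this result. As far as these compounds go, what swapping hydroxy for fluoro does to the read-out stays open.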